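Returning a brominated aryl group to the series

The source may report more compounds than this note shows. Statements on the series, on what has been measured and on what is new or still open speak of the compounds shown alone.

Compound 1 (`Cc1oc2c([C@H]3CCN(C)C[C@H]3O)c(O)cc(O)c2c(=O)c1C(O)c1ccccc1Br`) and compound 2 (`Cc1oc2c([C@H]3CCN(C)C[C@H]3O)c(O)cc(O)c2c(=O)c1C(O)c1csc([N+](=O)[O-])c1`) share one core and differ only in the aromatic group on a saturated chain carbon. In a functional assay on PC-3 cells (Homo sapiens) for inhibition, read by MTT assay, with a stated time of 48 h, tested at 10 uM (a lower number here means less inhibition of growth, a higher number more inhibition of growth at the concentration tested), compound 1 gives 45%, while compound 2 gives 0%, the lower of the two numbers. Among the compounds with values here, the only measured step is a number 45 percentage points lower from compound 1 to compound 2 (beyond the scatter), large and beyond the scatter, with 5-nitrothiophen-3-yl in place of 2-bromophenyl.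

Compound 3 (`CCOc1ccc(Br)c(C(O)c2c(C)oc3c([C@H]4CCN(C)C[C@H]4O)c(O)cc(O)c3c2=O)c1`) has 2-bromo-5-ethoxyphenyl in place of 5-nitrothiophen-3-yl on a saturated chain carbon bound to an aromatic carbon and an oxygen on a saturated carbon. The entering group keeps the 2-bromophenyl of compound 1 and adds an ethoxy group. The step of a number 45 percentage points lower from compound 1 to compound 2 (beyond the scatter) therefore bears on this change when read in reverse, so a large rise in this assay is expected. Within the data shown here, no measured compound shows what the ethoxy group adds, which leaves the size uncertain. The expected step is a number 38 percentage points higher from compound 2 to compound 3 (beyond the scatter). For compound 3 the estimated value is 38%, with an expected range from 15% to 60%.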

Compound 3, percent growth inhibition at one concentration: 0%
Compound 3: middle estimate off by 38 percentage points, on the high side, and the stated range ends above it.
By their numbers in this assay, from the lowest: compounds 2 and 3 (each within the scatter of the next); then compound 1.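

Ethoxy in place of hydrogen on an aromatic carbon gives a number 45 percentage points lower from compound 1 to compound 3 (beyond the scatter) in this assay, so this single added group is enough to lose all the growth inhibition that compound 1 shows at the concentration tested. With no change at the digits printed from compound 2 to compound 3 (within the scatter), the 2-bromo-5-ethoxyphenyl and 5-nitrothiophen-3-yl groups cannot be told apart here, and the bromine on the aromatic ring does not by itself keep the inhibition seen with compound 1. Nothing available bears on why the ethoxy group has this effect.

Going by these compounds, it remains open whether the loss is specific to ethoxy or also follows from a smaller group at the same place, such as methoxy or hydroxy in place of the ethoxy. Plain phenyl in place of 2-bromophenyl would show what the bromine contributes to the value of compound 1, while compound 2 and compound 3 both read 0% at this single concentration, so any difference between them cannot be seen in this assay.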